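The source may hold more compounds than are shown below. What is called first, only, known or untested is meant among the compounds shown, and "the series" means these compounds.

Of the compounds shown here, three that share one core have been measured in an assay for binding affinity to 5-hydroxytryptamine receptor 1F (Homo sapiens), read by radioligand binding; a lower number here means a stronger inhibitor, a higher number a weaker inhibitor. Compound 1 `CN1CCC(c2c[nH]c3cnc(NC(=O)c4ccc(F)cc4)cc23)CC1` gives 13 nM. Compound 2 `COc1ccccc1C(=O)Nc1ccc2[nH]cc(C3CCN(C)CC3)c2n1` gives 20 nM. Compound 3 `CCN1CC=C(c2c[nH]c3ccc(NC(=O)c4ccc(F)cc4)nc23)CC1` gives 25 nM, the highest of the three numbers, yet its gap to compound 2 and its gap to compound 1 both fall within the usual scatter of repeated measurements, so no real ordering among the three can be read from these values. Every one of the measured compounds carries an aromatic ring on the amide carbonyl.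

Compound 4 `CCN1CC=C(c2c[nH]c3ccc(NC(C)=O)nc23)CC1` has not yet been measured. It differs from compound 3 in a single place: methyl in place of 4-fluorophenyl on a carbonyl carbon. Going by the values given here, with this change the aromatic ring on that carbonyl is gone, and none of the measured compounds shows what a small group in that place does, so no measured step covers this change. The step from compound 3 to compound 4 in this assay is expected to be a clear rise in the number, of about a 12-fold higher number from compound 3 to compound 4 (1.08 log units; beyond the scatter), well beyond the scatter. Compound 4 is therefore estimated to give roughly 300 nM in this assay, with a likely range from 80 nM to 1500 nM.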

Compound 4, inhibition constant: 21 nM
Beside the measured number, compound 4's estimate is 14-fold (1.15 log units) above it; the measured number lies below the stated range.
By their numbers in this assay, from the lowest: compounds 1, 2, 4 and 3 (each within the scatter of the next).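

In this assay, putting methyl in place of 4-fluorophenyl on the carbonyl carbon gives a 1.2-fold lower number from compound 3 to compound 4 (0.08 log units; within the scatter) and so leaves no change that can be read. Every earlier compound carried an aromatic ring on the amide carbonyl, so those compounds could not show what happens without one; this pair shows that, with the rest of compound 3 held the same, the number in this range does not depend on that ring, and a single methyl serves as well as the much larger 4-fluorophenyl. No measurement here explains why the ring can go without a readable change in the number.

As far as these compounds go, this finding rests on one pair, so it remains unknown whether the same swap would be as uneventful on the core of compound 1 or alongside the other groups carried by compound 1 and compound 2. From the compounds shown here alone, it also remains open what other groups on this carbonyl carbon would do, such as a longer chain like butyl, an amine or a carboxylic acid, since methyl and the aromatic rings are the only kinds seen there so far.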